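A few compounds are considered here, and "the series" means these few. Any claim that something is new, unique, unknown or untested is made for them only; others in the source may bear on it.

Three compounds have been measured in a functional assay on KM12 cells (Homo sapiens) for inhibition, read by sulforhodamine B assay, with a stated time of 48 h (a higher number here means a weaker inhibitor of growth, a lower number a stronger inhibitor of growth), so far:

Compound 1 (`O=C(Cc1csc2nc(-c3ccc(Br)cc3)cn12)N/N=C/c1ccccc1`) – 26300 nM
Compound 2 (`O=C(Cc1csc2nc(-c3ccc(Br)cc3)cn12)N/N=C/c1ccccc1O`) – 3630 nM
Compound 3 (`O=C(Cc1csc2nc(-c3ccc(Br)cc3)cn12)N/N=C/c1ccc(O)cc1`) – 17800 nM

Compound 3 sits within the scatter of compound 1 (a 1.5-fold lower number from compound 1 to compound 3 (0.17 log units; within the scatter)) but clearly apart from compound 2 (a 4.9-fold higher number from compound 2 to compound 3 (0.69 log units; beyond the scatter)). Compound 4 (`COc1cccc(OC)c1/C=N/NC(=O)Cc1csc2nc(-c3ccc(Br)cc3)cn12`) differs from compound 3 by one change (2,6-dimethoxyphenyl in place of 4-hydroxyphenyl on a carbon with a double bond to nitrogen). Among the compounds with values here, the only measured steps on this ring concern a hydroxy group: the two above and one more modest step (a 7.2-fold lower number from compound 1 to compound 2 (0.86 log units; beyond the scatter)). None involves a methoxy group, so they set only a rough scale and give no direction. No step beyond the scatter is therefore expected in this assay and the estimate is small (a 1.8-fold lower number from compound 3 to compound 4 (0.25 log units; within the scatter)) in size. Compound 4 is expected at 10000 nM with an estimated range from 3000 nM to 35000 nM around it.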

Compound 4, concentration for 50% growth inhibition: 8910 nM
Compound 4: middle estimate off by 1.1-fold (0.05 log units), on the high side, within the range that was stated.
By their numbers in this assay, from the lowest: compound 2; then compounds 4, 3 and 1 (each within the scatter of the next, the first and the last beyond it).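

In this assay, a ring with no hydroxy group can still lower the number at this position: 2,6-dimethoxyphenyl in place of phenyl gives a step beyond the scatter (a 3.0-fold lower number from compound 1 to compound 4 (0.47 log units; beyond the scatter)), though 2-hydroxyphenyl still gives the lower number (a 2.5-fold higher number from compound 2 to compound 4 (0.39 log units; beyond the scatter)). Against 4-hydroxyphenyl, the change stays within the scatter (a 2.0-fold lower number from compound 3 to compound 4 (0.30 log units; within the scatter)). No measured evidence accounts for these steps.

From the compounds shown here alone, it remains open whether a ring with a single methoxy group would match the 2,6-dimethoxyphenyl ring. The effect of an amine or a carboxylic acid on this ring is also unknown.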